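From a bromophenyl to a sulfonamide arm

A few compounds are considered here, and "the series" means these few. Any claim that something is new, unique, unknown or untested is made for them only; others in the source may bear on it.

Compound 1 `O=C1O[C@H]([C@@H](O)Cn2cc(-c3ccc(Br)cc3)nn2)C(OCc2ccccc2)=C1OCc1ccccc1` is tested in a functional assay on HeLa cells (Homo sapiens) for antiproliferative activity, read by MTT assay, with a stated time of 72 h (a higher number here means a weaker inhibitor, a lower number a stronger inhibitor), where compound 1 gives 3910 nM. Of the two numbers that are not limits, this is the lowest; the other belongs to compound 2 `Cc1ccc(-c2cn(C/C=C3\OC(=O)C(OCc4ccccc4)=C3OCc3ccccc3)nn2)cc1`, which in this assay gives 7480 nM, a difference that stays within the usual scatter, so the two cannot be ranked against each other. Compound 3 `CC(C)(C)OC(=O)N1CCN(C(=S)SCc2cn(C[C@H](O)[C@H]3OC(=O)C(OCc4ccccc4)=C3OCc3ccccc3)nn2)CC1` reached only the limit of this assay, > 100000 nM, so no number is known for it. In compound 4 `O=C1O[C@H]([C@@H](O)Cn2cc(CNS(=O)(=O)c3ccc(F)cc3)nn2)C(OCc2ccccc2)=C1OCc1ccccc1` the change from compound 1 is (((4-fluorophenyl)sulfonyl)amino)methyl in place of 4-bromophenyl on an aromatic carbon. Among the measured compounds shown here, no step between two measured compounds mirrors this change, so the expectation rests on the spread of the measured set alone, in which one compound, compound 3, sits at the limit (the limit of > 100000 nM in this assay, at which 1 of the 3 values shown sits). For compound 4 the estimated step is a 5.1-fold higher number from compound 1 to compound 4 (0.71 log units; beyond the scatter), toward a weaker inhibitor by more than the scatter, and compound 4 is expected to give about 20000 nM, with a range from 5000 nM to 100000 nM.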

Compound 4, half-maximal inhibitory concentration: 25000 nM
The estimate for compound 4 lay 1.3-fold (0.10 log units) below the measured number; measured number inside the range.
By their numbers in this assay, from the lowest: compounds 1 and 2 (each within the scatter of the next); then compound 4. At a limit, above all of these: compound 3.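

Swapping 4-bromophenyl for (((4-fluorophenyl)sulfonyl)amino)methyl on this aromatic carbon gives a 6.4-fold higher number from compound 1 to compound 4 (0.81 log units; beyond the scatter) in this assay, the only step at this position that can be read. This shows that the position is sensitive to what it carries, although the step is modest and compound 4 still gives a real number. Compound 3 remains a limit of the assay and not a number: the limit of > 100000 nM in this assay, at which 1 of the 4 values shown sits.

The new arm differs from 4-bromophenyl in several features at once, including its sulfonyl group and its hydrogen-bond donor, so these compounds cannot show which feature accounts for the step. From the compounds shown here alone, it also remains open how a plain 4-fluorophenyl, an amine or a carboxylic acid at this position would compare with compound 1.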